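Swapping the ester tail of a dihydropyridine calcium-channel blocker

The source may report more compounds than this note shows. Statements on the series, on what has been measured and on what is new or still open speak of the compounds shown alone.

Measured so far:
Compound 1, `CCOC(=O)C1=C(C)NC(CN2CCN(c3ccccc3)CC2)=C(C(=O)OCC)C1c1cccc([N+](=O)[O-])c1`: 630 nM
Compound 2, `C#CCCOC(=O)C1=C(C)NC(C)=C(C(=O)OC)C1c1cccc([N+](=O)[O-])c1`: 31 nM

Both compounds were tested in a functional assay on HEK293 cells for antagonist activity at Voltage-dependent L-type calcium channel subunit alpha-1C (Oryctolagus cuniculus), read by FLIPR; a lower number here means a stronger inhibitor, a higher number a weaker inhibitor. Compound 2 gives 31 nM, the lowest of the two numbers and therefore the stronger inhibitor here; compound 1 gives 630 nM, a gap that lies well beyond the usual scatter of this assay. Within the data shown here, with only two compounds and no pair differing in a single place, no single structural change can be tied to that gap.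

Compound 3, `COC(=O)C1=C(C)NC(C)=C(C(=O)OCCOc2ccccc2Cl)C1c1cccc([N+](=O)[O-])c1`, has not yet been measured. It differs from compound 2 in one place: 2-chlorophenoxy in place of ethynyl on a saturated chain carbon, two bonds along the chain from an oxygen next to a carbonyl group. The ester chain is kept, but its end is exchanged, so the tail becomes 2-(2-chlorophenoxy)ethyl in place of but-3-yn-1-yl.

Among the measured compounds shown here, no measured pair shows what such an exchange does. The shared core is unchanged, so the step from compound 2 to compound 3 is expected to be small, a 1.6-fold lower number from compound 2 to compound 3 (0.19 log units; within the scatter), at most modestly toward a lower number. Compound 3 is therefore estimated at 20 nM, within a range of 5 nM to 80 nM.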

Compound 3, half-maximal inhibitory concentration: 19 nM
Estimate against measurement, compound 3: 1.1-fold (0.02 log units) above, within the range that was stated.
By their numbers in this assay, from the lowest: compounds 3 and 2 (each within the scatter of the next); then compound 1.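

In this assay, replacing ethynyl with 2-chlorophenoxy on a saturated chain carbon, two bonds along the chain from an oxygen next to a carbonyl group, gives a step that stays within the scatter (a 1.6-fold lower number from compound 2 to compound 3 (0.21 log units; within the scatter)). Among these compounds, this is the first comparison here that isolates one place, and it shows that the ester tail can be but-3-yn-1-yl or the much larger 2-(2-chlorophenoxy)ethyl, with its six-membered aromatic ring and added hydrogen-bond acceptor, and the two compounds still cannot be told apart in this measurement. Nothing available here explains why two such different tails read alike.

The compounds shown leave open which part of the new tail matters, since neither a plain phenoxy group without the chlorine nor a 2-fluorophenoxy group appears among them. They also leave open how far this freedom extends, for instance to a tail ending in an amine or a carboxylic acid, or to a longer chain between the ester oxygen and the aromatic ring.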